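The source may report more compounds than this note shows. Statements on the series, on what has been measured and on what is new or still open speak of the compounds shown alone.

Compound 1 `CCCCCCCCOC(=O)CN(C)C(=N)N` and compound 2 `CCCCCCCCCCCCCCCCCCOC(=O)CN(C)C(=N)N` share the same core. In an ADME assay (Rattus norvegicus) for activation, read by fluorescence, with a stated time of 60 min, tested at 1 ug/mL (on this read-out lower numbers stand for lower permeability and higher numbers for higher permeability), compound 1 gives 0.93 10^-6 cm/s, while the result for compound 2 reads "not determined" (no result reported), so compound 2 has no place on the numeric scale. Compound 3 `CCCCCCCCCCCCOC(=O)CN(C)C(=N)N` is still unmeasured. The structural change is hydrogen in place of hexyl on a saturated chain carbon, ten or more bonds along the chain from an oxygen next to a carbonyl group. Among the compounds with values here, with no number at the starting end, the only guide is compound 1 at 0.93 10^-6 cm/s, and no step beyond the usual scatter from that value is expected. Compound 3 is estimated at 1 10^-6 cm/s, with an expected range from 0.4 10^-6 cm/s to 2.5 10^-6 cm/s.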

Compound 3, apparent permeability in the Rattus norvegicus assay: 0.7 10^-6 cm/s
The estimate for compound 3 lay 1.4-fold (0.15 log units) above the measured number, within the range that was stated.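

Butyl in place of hydrogen on a saturated chain carbon, eight bonds along the chain from an oxygen next to a carbonyl group, leaves compound 1 and compound 3 indistinguishable in the Rattus norvegicus assay: a 1.3-fold lower number from compound 1 to compound 3 (0.12 log units; within the scatter). In this pair, the longer chain brings no change beyond the scatter. In a physicochemical assay for lipophilicity (a higher number here means a more lipophilic compound, a lower number a more polar compound), compound 2 gives 5.59 and compound 3 gives 3.81. A further chain change does shift the physicochemical assay: the measured partition coefficient of compound 2, 5.59, and of compound 3, 3.81, a number 1.78 log units lower (beyond the scatter)

From the compounds shown here alone, with no number for compound 2 in the Rattus norvegicus assay, the effect of hexyl at this place on that read-out stays open. The compounds shown also leave open what an amine or a carboxylic acid in place of hexyl would do.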